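Replacing the group on the amine nitrogen of compound 2

The source may hold more compounds than are shown below. What is called first, only, known or untested is meant among the compounds shown, and "the series" means these compounds.

Compound 1 `CCOC(=O)C1=C(N/C=N/c2ccc(C)cc2)Nc2[nH]nc(C)c2C1c1ccc(N(C)C)cc1`: 43200 nM
Compound 2 `CCOC(=O)C1=C(N/N=C(/C(=O)Br)c2ccc(Cl)cc2)Nc2[nH]nc(C)c2C1c1ccc(N(C)C)cc1`: 49300 nM

For the measured compounds named here, in a functional assay on HeLa cells (Homo sapiens) for inhibition, read by MTT assay, with a stated time of 48 h (a lower number here means a stronger inhibitor, a higher number a weaker inhibitor), compound 2 lies within the scatter of compound 1, and these are the only two numbers available. Compound 3 `CCOC(=O)C1=C(N/C=N/c2ccc([N+](=O)[O-])cc2)Nc2[nH]nc(C)c2C1c1ccc(N(C)C)cc1` departs from compound 2 by one change: a group of 11 heavy atoms (7 carbon, 2 nitrogen, 2 oxygen; one six-membered aromatic ring of carbon only) in place of a group of 12 heavy atoms (8 carbon, 1 nitrogen, 1 oxygen, 1 chlorine, 1 bromine; one six-membered aromatic ring of carbon only), on an amine nitrogen. Going by the values given here, the only measured change on this amine nitrogen is a 1.1-fold higher number from compound 1 to compound 2 (0.06 log units; within the scatter), so no step beyond the scatter is expected. The expected step is a 1.2-fold lower number from compound 2 to compound 3 (0.07 log units; within the scatter). For compound 3 the estimated value is 42000 nM, with an expected range from 20000 nM to 85000 nM.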

Compound 3, half-maximal inhibitory concentration: 57800 nM
Compound 3: the middle estimate sits 1.4-fold (0.14 log units) below what was measured; the range from low to high includes it.
By their numbers in this assay, from the lowest: compounds 1, 2 and 3 (each within the scatter of the next).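

In this assay the exchange on the amine nitrogen gives a 1.2-fold higher number from compound 2 to compound 3 (0.07 log units; within the scatter) and so adds a third group at this position with no step beyond the scatter. Nitro in place of methyl on an aromatic carbon gives a 1.3-fold higher number from compound 1 to compound 3 (0.13 log units; within the scatter) and is the first reading of a single substituent on that aromatic ring, again within the scatter. Nothing measured here gives a reason for these readings. Still open, from the compounds shown here alone, is whether an amine or a carboxylic acid on that aromatic carbon, or a longer chain on the amine nitrogen, would give a step beyond the scatter.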